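Replacing fluoro with methyl on compound 3

The compounds below may be only part of what the source reports. "The series", "measured", "known", "first", "only" and "open" are said of these compounds alone.

In a physicochemical assay for solubility, in phosphate buffer, at pH 7.4 (a lower number here means a less soluble compound, a higher number a more soluble compound), compound 3 (`CC(=O)N[C@@H]1CCC[C@H](C(=O)Nc2cc(-c3cnn4c3CC(C)(C)C4)c(F)cn2)C1`) has the higher of the two actual numbers (550000 nM). Compound 2 (`CC(=O)N[C@@H]1CCC[C@H](C(=O)Nc2cc(-c3cnn4c3COCC4)c(Cl)cn2)C1`) gives the lower one (220000 nM). The reading for compound 1 (`CC(=O)N[C@@H]1CCC[C@H](C(=O)Nc2cc(-c3cnn4c3CCCC4)c(F)cn2)C1`) is a limit of the assay, not a number (> 1000000 nM).

Compound 4 (`CC(=O)N[C@@H]1CCC[C@H](C(=O)Nc2cc(-c3cnn4c3CC(C)(C)C4)c(C)cn2)C1`) carries methyl in place of fluoro on an aromatic carbon. Among the compounds with values here, the only measured step (an at least 1.8-fold lower number from compound 1 to compound 3 (0.25 log units; that floor lies within the scatter)) changes a different part of the molecule, so it offers no direct guide to this swap. Within the data shown here, with no measured step for this change, a shift within the scatter is expected, and the estimated step is small (a 1.4-fold lower number from compound 3 to compound 4 (0.14 log units; within the scatter)). For compound 4 the estimated solubility is 400000 nM, with an expected range from 150000 nM to 1000000 nM.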

Compound 4, solubility: 600000 nM
Compound 4: the middle estimate sits 1.5-fold (0.18 log units) below what was measured, and the stated range covers the measured number.
By their numbers in this assay, from the lowest: compound 2; then compounds 3 and 4 (each within the scatter of the next). At a limit, above all of these: compound 1.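

In this assay, methyl in place of fluoro gives a 1.1-fold higher number from compound 3 to compound 4 (0.04 log units; within the scatter), so compound 3 and compound 4 cannot be told apart in this measurement. This is the only step shown at this position, since the earlier step between compounds changed a different part of the molecule. On this core, then, the swap of these two small groups leaves no readable mark.

On these data alone, what an amine or a carboxylic acid at this position would give stays open. The reading for compound 1 is a limit, not a number: the limit of > 1000000 nM in this assay, at which 1 of the 4 values shown sits.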